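The compounds below may be only part of what the source reports. "The series", "measured", "known", "first", "only" and "open" are said of these compounds alone.

Measured in a functional assay on U-87MG ATCC cells for antiproliferative activity against U-87 MG (Homo sapiens), read by spectrophotometry, with a stated time of 2 days; a higher number here means a weaker inhibitor of growth, a lower number a stronger inhibitor of growth:
- Compound 1 `COc1ccc(C(F)(F)F)cc1Nc1ncc(C(F)(F)F)c(N2Cc3cccc(N(C)S(C)(=O)=O)c3C2)n1`: > 30000 nM, a limit
- Compound 2 `Cc1ccc(Nc2ncc(C(F)(F)F)c(N3Cc4cccc(N(C)S(C)(=O)=O)c4C3)n2)c(Cl)c1`: > 30000 nM, a limit

Neither entry is a number. Together they read: the limit of > 30000 nM in this assay, at which 2 of the 2 values shown sit. Among the compounds with values here, compound 2 therefore has no exact position, and the only other value available to compare it with is also a limit.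

Not yet measured in this assay is compound 3 `Cc1cc(F)ccc1Nc1ncc(C(F)(F)F)c(N2Cc3cccc(N(C)S(C)(=O)=O)c3C2)n1`. It carries 4-fluoro-2-methylphenyl in place of 2-chloro-4-methylphenyl on a nitrogen on an aromatic ring.

Within the data shown here, the only measured step that bears on this change is a step that the two limits leave unreadable from compound 1 to compound 2. It replaces the group on the same nitrogen but gives no size to carry forward. No step beyond the scatter can therefore be predicted, in either direction, and the likeliest report for compound 3 is again a limit.

The expectation rests on compound 2 at > 30000 nM, a limit. The expected change is a number no higher from compound 2 to compound 3 (the limit leaves the size open). Compound 3 is estimated at 30000 nM, with an expected range from 12000 nM to 60000 nM.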

Compound 3, concentration for 50% growth inhibition: > 30000 nM
Compound 3: no number, only a limit (the forecaster's own chance of this, stated with the estimate: 75%); the middle value sits exactly at the limit.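

In this assay compound 3 gives > 30000 nM, a limit and not a number. No step among compound 1, compound 2 and compound 3 can be read, because all three stand only at the limit: the limit of > 30000 nM in this assay, at which 3 of the 3 values shown sit.

The compounds shown leave open how these three differ in growth inhibition, and whether any group on this nitrogen gives a measurable value.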